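Pyridin-3-yl Added to Compound 1: Expected Solubility

This account rests on a few compounds, and the source may have more. Where it says the series, first, only, none or still open, it means among the compounds named here.

Compound 1 `CNC(=O)c1cc(Oc2ccc3nc(Nc4ccccc4)ncc3c2)ccn1` was examined in a physicochemical assay for solubility, at pH 7; a higher number here means a more soluble compound, a lower number a less soluble compound. In this assay compound 1 returns only a limit of the assay, < 1000 nM. Compound 2 `CCc1ccccc1Nc1ncc2cc(Oc3ccnc(C(=O)NC)c3)ccc2n1` also gives a limit in this assay, < 1000 nM. Compound 3 `CNC(=O)c1cc(Oc2ccc3nc(Nc4cccc(OC(F)(F)F)c4)ncc3c2)ccn1` likewise sits at a limit in this assay, < 1000 nM. The steps a step that the two limits leave unreadable from compound 1 to compound 2, a step that the two limits leave unreadable from compound 1 to compound 3 and a step that the two limits leave unreadable from compound 2 to compound 3 cannot be sized because of the limit of < 1000 nM in this assay, at which 3 of the 3 values shown sit.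

Compound 4 `CNC(=O)c1cc(Oc2ccc3nc(Nc4ccc(-c5cccnc5)cc4)ncc3c2)ccn1` differs from compound 1 by pyridin-3-yl in place of hydrogen on an aromatic carbon. For the measured compounds named here, no measured step bears directly on this change, and all three values shown are limits, so no step size in this assay can be read in either direction. Compound 4 is therefore estimated at 500 nM, within 100 nM to 2000 nM, most likely reported again as a limit. The step that the limit leaves unreadable from compound 1 to compound 4 is expected to stay within the scatter.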

Compound 4, solubility: < 1000 nM
Compound 4 gave a limit, no number; the forecaster's own chance of this, stated with the estimate: 80%; the middle value does not contradict the limit.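

The step from compound 1 to compound 4 cannot be read in this assay, as both compounds give only a limit: the limit of < 1000 nM in this assay, at which 4 of the 4 values shown sit.

The compounds shown leave open where any of the four actually stands in this assay, and what size of step pyridin-3-yl brings.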